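Methoxy in place of chloro on compound 1

The source may report more compounds than this note shows. Statements on the series, on what has been measured and on what is new or still open speak of the compounds shown alone.

- compound 1 (`COc1cc(CCc2ccccc2Cl)cc(OC)c1O`) gives 21100 nM
- compound 2 (`COc1cc(CCc2cccc(Cl)c2Cl)cc(OC)c1O`) gives 6870 nM
- compound 3 (`COc1cc(CCc2ccc(Cl)cc2Cl)cc(OC)c1O`) gives > 25000 nM
- compound 4 (`COc1ccccc1CCc1cc(OC)c(O)c(OC)c1`) is not yet measured

In a functional assay on MDA-MB-231 cells (Homo sapiens) for antiproliferative activity, read by MTT assay, with a stated time of 72 h (a higher number here means a weaker inhibitor, a lower number a stronger inhibitor), compound 1 gives 21100 nM as the higher of the two actual numbers in the series. Compound 3 reports only a limit (> 25000 nM).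

Compound 4 carries methoxy in place of chloro on an aromatic carbon, ortho to a large group (methoxy in place of chloro on an aromatic carbon). Going by the values given here, two measured steps bear on this only indirectly, each chloro in place of hydrogen on an aromatic carbon: a 3.1-fold lower number from compound 1 to compound 2 (0.49 log units; beyond the scatter) is modest, while an at least 1.1-fold higher number from compound 1 to compound 3 (0.07 log units; that floor lies within the scatter) has a floor within the scatter. Neither alters the chloro that leaves, and they share no direction, so no step beyond the scatter is expected in this assay for this change. The expected step is a 1.2-fold lower number from compound 1 to compound 4 (0.07 log units; within the scatter) on this estimate. Compound 4 is estimated at 18000 nM (expected range 7000 nM to 40000 nM).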

Compound 4, half-maximal inhibitory concentration: > 25000 nM
Compound 4 gave a limit, no number; the forecaster's own chance of this, stated with the estimate: 30%; middle value at least 1.3-fold (0.14 log units) away from the limit.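

In this assay compound 4 reports a limit and not a number: the limit of > 25000 nM in this assay, at which 2 of the 4 values shown sit. The earlier steps shown here left this chloro in place, whereas here it is the group replaced, and the result is an at least 1.1-fold higher number from compound 1 to compound 4 (0.07 log units; that floor lies within the scatter). Methoxy in place of chloro, ortho to a large group, therefore gives no lower number than compound 1 in this assay.

Going by these compounds, how far compound 4 actually lies from compound 1 stays open. Also open, on these data alone, is whether fluoro or an amine at this place would give a measurable number.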